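A few compounds are considered here, and "the series" means these few. Any claim that something is new, unique, unknown or untested is made for them only; others in the source may bear on it.

Compound 2 `CCc1cccc(Nc2cc(NC(=O)Nc3cc(OC)cc(OC)c3)ncn2)c1` stands lowest on the three numbers shown in a functional assay on NCI-H520 cells (Homo sapiens) for inhibition, read by MTT assay, with a stated time of 48 h, tested at 10 uM; a higher number here means more inhibition at the concentration tested (going by the name of the read-out), a lower number less inhibition: compound 2 gives 23%. Compound 3 `COc1ccc(Nc2cc(NC(=O)Nc3c(Cl)cccc3Cl)ncn2)cc1C` comes nearest, and compound 3 gives 29.1%, which sits within the scatter of compound 2. Compound 1 `COc1ccc(OC)c(Nc2cc(NC(=O)Nc3c(Cl)cccc3Cl)ncn2)c1` lies furthest off, and compound 1 gives 74%, beyond the scatter. Compound 4 `COc1cc(NC(=O)Nc2cc(Nc3cc(F)ccc3OC)ncn2)cc(OC)c1` is not yet measured in this assay. The change from compound 2 to compound 4 reads (5-fluoro-2-methoxyphenyl in place of 3-ethylphenyl on a nitrogen on an aromatic ring). For the measured compounds named here, no two measured compounds differ in this one place, so the step has no precedent. The step is expected to be small and upward, a number 12 percentage points higher from compound 2 to compound 4 (beyond the scatter), because compound 1 at 74% shows that the series does reach markedly higher numbers. Compound 4 is estimated at 35%, with a range from 15% to 60%.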

Compound 4, a percentage reported as inhibition, at one concentration (the size of the read-out at that concentration, not a potency): 38%
Beside the measured number, compound 4's estimate is 3 percentage points below it, and the stated range covers the measured number.
By their numbers in this assay, from the lowest: compounds 2, 3 and 4 (each within the scatter of the next, the first and the last beyond it); then compound 1.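

In this assay, for the compounds shown here, the swap of 3-ethylphenyl for 5-fluoro-2-methoxyphenyl on a nitrogen on an aromatic ring gives a number 15 percentage points higher from compound 2 to compound 4 (beyond the scatter) as the first single-place step. This position therefore responds to a change of its aryl group, though the step is modest. Nothing at hand accounts for the gain.

Still open, going by these compounds, is whether the methoxy or the fluorine carries the step, a question that 2-methoxyphenyl and 3-fluorophenyl would address. Also open, on these data alone, is how a non-aromatic group, such as a cyclohexyl, would fare on this nitrogen.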